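The source may report more compounds than this note shows. Statements on the series, on what has been measured and on what is new or still open speak of the compounds shown alone.

Of the compounds shown here, three share one core and have been measured in a functional assay on MGC-803 cells (Homo sapiens) for inhibition, read by MTT assay, with a stated time of 72 h; a higher number here means a weaker inhibitor, a lower number a stronger inhibitor. Compound 1 `Cc1ccc(C(=O)Nc2ccc(CNC(=O)OCc3cccnc3)cc2)c(N2CCCC2)c1` reaches only the assay limit, > 100000 nM. Compound 2 `O=C(NCc1ccc(NC(=O)c2cc(Cl)ccc2N2CCCC2)cc1)OCc1cccnc1` gives 55500 nM, and compound 3 `Cc1ccc(N2CCCC2)c(C(=O)Nc2ccc(CNC(=O)OCc3cccnc3)cc2)c1` gives 19100 nM. For the measured compounds named here, the step of a 2.9-fold lower number from compound 2 to compound 3 (0.46 log units; beyond the scatter) is the only measured step, and it leaves compound 3 with the lowest of the two numbers, with compound 2 the nearest. Compound 4 `COc1ccc(N2CCCC2)c(C(=O)Nc2ccc(CNC(=O)OCc3cccnc3)cc2)c1` differs from compound 3 by one change: methoxy in place of methyl on an aromatic carbon. Going by the values given here, no measured step exchanges methyl for methoxy, so the exchange of chloro for methyl is only a loose guide, and no step beyond the scatter is expected. The expected step is a 1.0-fold higher number from compound 3 to compound 4 (0.02 log units; within the scatter). Compound 4 is therefore estimated at 20000 nM, within a range from 7000 nM to 60000 nM.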

Compound 4, half-maximal inhibitory concentration: 85700 nM
Compound 4: the middle estimate sits 4.3-fold (0.63 log units) below what was measured; the whole stated range lies below it.
By their numbers in this assay, from the lowest: compound 3; then compounds 2 and 4 (each within the scatter of the next). At a limit, above all of these: compound 1.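

At this position, para to a pyrrolidin-1-yl group, this assay responds to methoxy as well: the change gives a 4.5-fold higher number from compound 3 to compound 4 (0.65 log units; beyond the scatter) and so undoes the gain seen with methyl. Methoxy and chloro remain level, with a 1.5-fold higher number from compound 2 to compound 4 (0.19 log units; within the scatter), leaving methyl alone apart from both. Nothing measured here explains why methyl differs from these two groups.

From the compounds shown here alone, whether an ethyl group, a fluoro group or an amine at this position would match methyl or instead match methoxy and chloro remains open.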